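This account rests on a few compounds, and the source may have more. Where it says the series, first, only, none or still open, it means among the compounds named here.

Measured so far in a functional assay on HCT-15 cells (Homo sapiens) for cytotoxicity, read by CCK-8 assay and cell counting, with a stated time of 2 days; a lower number here means a stronger inhibitor, a higher number a weaker inhibitor:
compound 1 `Oc1ccc(-c2cc(-c3ccc(Cl)cc3)nc(-c3cccnc3)c2)cc1` gives 20700 nM
compound 2 `Oc1ccc(-c2cc(-c3ccc(Cl)cc3)nc(-c3cccs3)c2)cc1` gives 6470 nM
compound 3 `Oc1ccc(-c2cc(-c3cccc(Cl)c3)nc(-c3cccs3)c2)cc1` gives 5050 nM

Compound 2 and compound 3 are built from the same atoms joined differently; the difference is 3-chlorophenyl in place of 4-chlorophenyl on an aromatic carbon, and the step is a 1.3-fold lower number from compound 2 to compound 3 (0.11 log units; within the scatter), so these two are not separated by this assay. Compound 1 is obtained from compound 2 by pyridin-3-yl in place of thiophen-2-yl on an aromatic carbon, and that step is a 3.2-fold higher number from compound 2 to compound 1 (0.51 log units; beyond the scatter). Compound 3 stands at the lowest number of the three, but only its gap to compound 1 lies beyond the scatter.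

Compound 4 `Oc1ccc(-c2cc(-c3cccnc3)nc(-c3cccc(Cl)c3)c2)cc1` has not been measured in this assay. It is related to compound 3 by pyridin-3-yl in place of thiophen-2-yl on an aromatic carbon. This is the same kind of change as that from compound 2 to compound 1, not the same: around the place, compound 2 and compound 1 carry a 4-chlorophenyl group where compound 3 and compound 4 carry a 3-chlorophenyl group. The change has been measured once only, in the pair of compound 2 and compound 1, and there is no measured case of it on the core of compound 3.

The expectation for compound 4 rests on that single measured step. Compound 4 is expected to give 16000 nM in this assay, with a likely range from 8000 nM to 35000 nM. The step this estimate means is a 3.2-fold higher number from compound 3 to compound 4 (0.50 log units; beyond the scatter), set beside a 3.2-fold higher number from compound 2 to compound 1 (0.51 log units; beyond the scatter), and it starts from the number compound 3 gives at 5050 nM.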

Compound 4, half-maximal inhibitory concentration: 21300 nM
Compound 4: middle estimate off by 1.3-fold (0.12 log units), on the low side; the range from low to high includes it.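

In this assay, pyridin-3-yl in place of thiophen-2-yl on the core carrying the 3-chlorophenyl group gives a 4.2-fold higher number from compound 3 to compound 4 (0.63 log units; beyond the scatter), and this step does not differ from the one measured on the core carrying the 4-chlorophenyl group: the same change on two cores in this assay, a 3.2-fold higher number (0.51 log units; beyond the scatter) from compound 2 to compound 1 and a 4.2-fold higher number (0.63 log units; beyond the scatter) from compound 3 to compound 4, 1.3-fold (0.12 log units) apart, within the scatter of two such steps. The swap of 4-chlorophenyl for 3-chlorophenyl, now read with pyridin-3-yl in place, gives a 1.0-fold higher number from compound 1 to compound 4 (0.01 log units; within the scatter), and it leaves the two compounds unseparated, as it did with thiophen-2-yl in place: the same change on two cores in this assay, a 1.3-fold lower number (0.11 log units; within the scatter) from compound 2 to compound 3 and a 1.0-fold higher number (0.01 log units; within the scatter) from compound 1 to compound 4, 1.3-fold (0.12 log units) apart, within the scatter of two such steps. Across these four compounds the heteroaryl change carries from one core to the other at a similar size, and the chlorine position does not alter that reading, but this rests on two cores differing only in that chlorine position and says nothing about cores that differ in any other way.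

The compounds shown leave open how the number responds at the same place to a furan-2-yl group or to an open-chain amine. Also open, from the compounds shown here alone, is whether the step holds when the 4-hydroxyphenyl group carries a methoxy group in place of its hydroxyl, or when the chlorophenyl group carries a carboxylic acid in place of its chlorine.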